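Methoxy for Methyl on the Para Side of an Anilide

This account rests on a few compounds, and the source may have more. Where it says the series, first, only, none or still open, it means among the compounds named here.

Three anilide esters have been measured in an assay on isolated protein for inhibition of glutathione S-transferase Mu 2 (Homo sapiens), with a stated time of 10 min; on this read-out higher numbers stand for weaker inhibition and lower numbers for stronger inhibition. Compound 1 `Cc1ccccc1NC(=O)CCC(=O)OCCCCCCSc1ccc([N+](=O)[O-])c2nonc12` gives 440 nM in this assay. Compound 2 `COc1ccccc1NC(=O)CCC(=O)OCCCCCCSc1ccc([N+](=O)[O-])c2nonc12` differs by methoxy in place of methyl on an aromatic carbon and gives 280 nM; the step is a 1.6-fold lower number from compound 1 to compound 2 (0.20 log units; within the scatter). Compound 3 `Cc1ccc(NC(=O)CCC(=O)OCCCCCCSc2ccc([N+](=O)[O-])c3nonc23)cc1` differs from compound 1 by 4-methylphenyl in place of 2-methylphenyl on an amide-type nitrogen. In this assay compound 3 gives 390 nM, with the step of a 1.1-fold lower number from compound 1 to compound 3 (0.05 log units; within the scatter). Compound 4 `COc1ccc(NC(=O)CCC(=O)OCCCCCCSc2ccc([N+](=O)[O-])c3nonc23)cc1` is not yet measured; it differs from compound 3 by methoxy in place of methyl on an aromatic carbon. This is the same kind of change as that from compound 1 to compound 2, but the place differs: ortho to a large group there, para to a large group here. Resting on the step of a 1.6-fold lower number from compound 1 to compound 2 (0.20 log units; within the scatter), the expected step is a 1.4-fold lower number from compound 3 to compound 4 (0.16 log units; within the scatter), within the scatter. The estimate for compound 4 is 270 nM, expected between 120 nM and 600 nM.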

Compound 4, half-maximal inhibitory concentration: 130 nM
For compound 4 the middle estimate is 2.1-fold (0.32 log units) above the measured one; the range from low to high includes it.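

In this assay, methoxy in place of methyl para to a large group gives a 3.0-fold lower number from compound 3 to compound 4 (0.48 log units; beyond the scatter), and the two changes of anilide that also lead to compound 4 give a 2.2-fold lower number from compound 2 to compound 4 (0.33 log units; beyond the scatter) and a 3.4-fold lower number from compound 1 to compound 4 (0.53 log units; beyond the scatter). Set beside the same change on the other core, the step cannot be told apart in size: the same change on two cores in this assay, a 1.6-fold lower number (0.20 log units; within the scatter) from compound 1 to compound 2 and a 3.0-fold lower number (0.48 log units; beyond the scatter) from compound 3 to compound 4, 1.9-fold (0.28 log units) apart, within the scatter of two such steps The change thus lies beyond the scatter on only one of the two cores, so the pair does not show that its size depends on the place, nor that it would carry to a further core.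

The compounds shown leave open whether an ethoxy group or a chlorine atom in place of the methoxy would match compound 4. They also leave open whether the step would hold with a shorter chain in the linker.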